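Swapping hydroxy for trifluoromethyl in a weakly cytotoxic series

The source may report more compounds than this note shows. Statements on the series, on what has been measured and on what is new or still open speak of the compounds shown alone.

Compound 3 `CC(=O)N1c2ccccc2CCC1C(=O)Nc1ccccc1O` carries an acetyl on the ring nitrogen of the shared core and a hydroxy on the aromatic ring of the amide. In a functional assay on NUGC-3 cells (Homo sapiens) for cytotoxicity, read by sulforhodamine B assay, with a stated time of 72 h (a higher number here means a weaker inhibitor of growth, a lower number a stronger inhibitor of growth), compound 3 gives 49700 nM. Compound 1 `O=C(Nc1ccccc1C(F)(F)F)C1CCc2ccccc2N1` has a free hydrogen on that nitrogen and a trifluoromethyl on the amide ring; in this assay compound 1 gives 39300 nM, and compound 3 sits within the scatter of that number, so no order can be read between the two. Compound 2 `CCCC(=O)N1c2ccccc2CCC1C(=O)Nc1ccccc1C(F)(F)F` bears a propylcarbonyl on the nitrogen. For compound 2 this assay reports only a limit, > 70000 nM. Among the compounds with values here, the single measured step, an at least 1.7-fold higher number from compound 1 to compound 2 (0.25 log units; that floor lies within the scatter), concerns the nitrogen substituent and rests on (the limit of > 70000 nM in this assay, at which 1 of the 3 values shown sits); it does not touch the amide ring.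

Compound 4 `CC(=O)N1c2ccccc2CCC1C(=O)Nc1ccccc1C(F)(F)F` differs from compound 3 in one place: trifluoromethyl in place of hydroxy on an aromatic carbon. Within the data shown here, no measured pair shows this exchange, so the account can lean only on the fact that compound 1 and compound 3, which differ at both positions, lie within the scatter of each other. Compound 4 is therefore expected to sit near compound 3, with a 1.1-fold higher number from compound 3 to compound 4 (0.04 log units; within the scatter) estimated as no change beyond the scatter. Compound 4 is estimated at 55000 nM, within a range from 25000 nM to 120000 nM, and a limit rather than a number is a real possibility.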

Compound 4, concentration for 50% growth inhibition: > 80000 nM
Compound 4 gave a limit, no number; the forecaster's own chance of this, stated with the estimate: 40%; middle value at least 1.4-fold (0.16 log units) away from the limit.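

The exchange of hydroxy for trifluoromethyl on an aromatic carbon now has a measured pair, and in this assay it gives an at least 1.6-fold higher number from compound 3 to compound 4 (0.20 log units; that floor lies within the scatter), so the data establish no order between the two groups at this position. Acetyl in place of hydrogen on the ring nitrogen gives an at least 2.0-fold higher number from compound 1 to compound 4 (0.30 log units; that floor lies within the scatter), a second nitrogen step of the same kind as an at least 1.7-fold higher number from compound 1 to compound 2 (0.25 log units; that floor lies within the scatter), so with trifluoromethyl on the amide ring both compounds carrying a group on that nitrogen end at limits, while compound 1 gives a number. The value of compound 4 is a limit of the assay and not a number, and both new steps rest on it: the limit of > 80000 nM in this assay, at which 1 of the 4 values shown sits.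

The step between compound 2 and compound 4 cannot be read, both values being limits, so acetyl and propylcarbonyl on the nitrogen stay unordered. Going by these compounds, it remains open whether an amine or a carboxylic acid in place of hydroxy on that aromatic carbon, or a longer chain on the nitrogen, would give a number that stands beyond the scatter of compound 3.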